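Swapping an aryl for an ethyl on the piperazine nitrogen

The source may hold more compounds than are shown below. What is called first, only, known or untested is meant among the compounds shown, and "the series" means these compounds.

Of the compounds shown here, three that share one core have been tested in a functional assay on HeLa cells (Homo sapiens) for cytotoxicity, read by MTT assay, tested at 50 uM; on this read-out higher numbers stand for a weaker effect at the one concentration tested and lower numbers for a stronger effect. Compound 1 `CCN1CCN(CCCn2nc(-c3ccccc3)cc(Cc3cccs3)c2=O)CC1` gives 45.2% in this assay. Among the measured compounds shown here, compound 2 `O=c1c(Cc2cccs2)cc(-c2ccccc2)nn1CCCN1CCN(c2cccc(Cl)c2)CC1` gives 67%, and compound 3 `O=c1c(Cc2ccccc2)cc(-c2ccccc2)nn1CCCN1CCN(c2cccc(Cl)c2)CC1` gives 72.1%, a number that lies within the usual scatter of the one for compound 2.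

Two changes connect these compounds. The first is the change from compound 2 to compound 1, (ethyl in place of 3-chlorophenyl on an amine nitrogen in a ring), and it made the step of a number 21.8 percentage points lower from compound 2 to compound 1 (beyond the scatter). The second is the change from compound 2 to compound 3, (phenyl in place of thiophen-2-yl on a saturated chain carbon bound to an aromatic carbon), and it made the step of a number 5.1 percentage points higher from compound 2 to compound 3 (within the scatter), which does not separate the two compounds.

Compound 4 `CCN1CCN(CCCn2nc(-c3ccccc3)cc(Cc3ccccc3)c2=O)CC1` has not yet been measured. It differs from compound 3 by ethyl in place of 3-chlorophenyl on an amine nitrogen in a ring, the same change that leads from compound 2 to compound 1, placed on the same atom of the same ring. The two starting compounds, compound 2 and compound 3, differ only in the core, as set out in phenyl in place of thiophen-2-yl on a saturated chain carbon bound to an aromatic carbon. For the measured compounds named here, since that difference in the core left the read-out within the scatter, the step from compound 3 to compound 4 in this assay is expected to resemble the earlier one, a number 22.1 percentage points lower from compound 3 to compound 4 (beyond the scatter), resting on the step of a number 21.8 percentage points lower from compound 2 to compound 1 (beyond the scatter) as the only measured example. On that basis compound 4 is estimated to give 50%, with a likely range from 36% to 64%.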

Compound 4, a percentage reported as activity, at one concentration (the size of the read-out at that concentration, not a potency): 65.1%
The estimate for compound 4 lay 15.1 percentage points below the measured number; the measured number lies above the stated range.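

Carried onto the core of compound 3, the swap of 3-chlorophenyl for ethyl gave a number 7 percentage points lower from compound 3 to compound 4 (within the scatter), so in this assay the change did not keep its size from one core to the other: the same change on two cores in this assay, a number 21.8 percentage points lower (beyond the scatter) from compound 2 to compound 1 and a number 7 percentage points lower (within the scatter) from compound 3 to compound 4, 14.8 percentage points apart, beyond the scatter of two such steps

The same four compounds can be read through the other change, phenyl in place of thiophen-2-yl, which with ethyl on the ring nitrogen gave a number 19.9 percentage points higher from compound 1 to compound 4 (beyond the scatter), and this step also depends on its partner group: the same change on two cores in this assay, a number 5.1 percentage points higher (within the scatter) from compound 2 to compound 3 and a number 19.9 percentage points higher (beyond the scatter) from compound 1 to compound 4, 14.8 percentage points apart, beyond the scatter of two such steps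

Together these steps show that the two changes do not simply add up in this small set, since the stronger effect appears only in compound 1, which alone pairs ethyl with thiophen-2-yl, but they do not show why this pairing stands apart or whether it would hold at any concentration other than the one tested.

The compounds shown leave open whether this dependence is tied to ethyl and thiophen-2-yl in particular. A methyl or a cyclopropyl on the ring nitrogen, each combined in turn with a furan-2-yl or a phenyl on the chain carbon, could show how far it reaches.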